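Pyrrolyl for Thienyl on the Trifluoromethylphenyl Triazole Ester

The compounds below may be only part of what the source reports. "The series", "measured", "known", "first", "only" and "open" are said of these compounds alone.

Compound 1 `COC(=O)c1nc(-c2ccsc2)n(-c2ccc(F)cc2)n1`: 54000 nM
Compound 2 `COC(=O)c1nc(-c2ccc[nH]2)n(-c2ccc(F)cc2)n1`: 9010 nM
Compound 3 `COC(=O)c1nc(-c2ccsc2)n(-c2ccc(C(F)(F)F)cc2)n1`: a limit, > 100000 nM

In a functional assay on Jurkat cells (Homo sapiens) for inhibition, read by MTT assay, with a stated time of 72 h (a lower number here means a stronger inhibitor of growth, a higher number a weaker inhibitor of growth), compound 1 gives 54000 nM and compound 2 gives 9010 nM. For compound 3 this assay reports only a limit, > 100000 nM. The change 1H-pyrrol-2-yl in place of thiophen-3-yl on an aromatic carbon brought a 6.0-fold lower number from compound 1 to compound 2 (0.78 log units; beyond the scatter). The cores of compound 1 and compound 3 differ by trifluoromethyl in place of fluoro on an aromatic carbon, and an at least 1.8-fold higher number from compound 1 to compound 3 (0.26 log units; that floor lies within the scatter). Compound 4 `COC(=O)c1nc(-c2ccc[nH]2)n(-c2ccc(C(F)(F)F)cc2)n1` has not been measured; it carries the same kind of change as 1H-pyrrol-2-yl in place of thiophen-3-yl on an aromatic carbon, the place here being next to the ring atom that bears a large group rather than a 4-fluorophenyl group (7 heavy atoms). Because compound 3 sits at the limit of > 100000 nM in this assay, at which 1 of the 3 values shown sits, a starting number is lacking. Compound 4 is expected to give 30000 nM, between 10000 nM and 150000 nM. That expectation means an at least 3.3-fold lower number from compound 3 to compound 4 (0.52 log units; beyond the scatter), resting on the earlier step of a 6.0-fold lower number from compound 1 to compound 2 (0.78 log units; beyond the scatter).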

Compound 4, concentration for 50% growth inhibition: > 100000 nM
Compound 4: only a limit was reported; the forecaster's own chance of this, stated with the estimate: 30%; middle value at least 3.3-fold (0.52 log units) away from the limit.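

In this assay compound 4 gives > 100000 nM, which is a limit of the assay, and the step from compound 3 to compound 4 cannot be read: the limit of > 100000 nM in this assay, at which 2 of the 4 values shown sit. For the compounds shown here, the change to 1H-pyrrol-2-yl thus has only one readable step, a 6.0-fold lower number from compound 1 to compound 2 (0.78 log units; beyond the scatter), and nothing here shows whether that step carries over to the core of compound 3 or fails to. Trifluoromethyl in place of fluoro brings an at least 11-fold higher number from compound 2 to compound 4 (1.04 log units; beyond the scatter), but its size cannot be firmly set against the same change on the thiophen-3-yl core: the same change on two cores in this assay, an at least 1.8-fold higher number (0.26 log units; that floor lies within the scatter) from compound 1 to compound 3 and an at least 11-fold higher number (1.04 log units; beyond the scatter) from compound 2 to compound 4; the limit leaves it open whether they differ.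

The compounds shown leave open whether a carboxylic acid or an amide in place of the methoxycarbonyl group would bring the trifluoromethyl compounds into a measurable range.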